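Series notes: trifluoromethyl in place of fluoro on compound 3

The source may report more compounds than this note shows. Statements on the series, on what has been measured and on what is new or still open speak of the compounds shown alone.

Compound 1 `Oc1ccc(-c2cc(-c3ccc(F)cc3)cc(-c3ccccc3O)n2)cc1` sits only at the assay limit of > 50000 nM in a functional assay on DU-145 cells (Homo sapiens) for inhibition; on this read-out lower numbers stand for stronger inhibition and higher numbers for weaker inhibition.
Compound 2 `Oc1ccc(-c2cc(-c3ccc(F)cc3)cc(-c3cccc(O)c3)n2)cc1` gives 15200 nM in this assay.
Compound 3 `Oc1ccc(-c2cc(-c3ccc(F)cc3)cc(-c3ccc(O)cc3)n2)cc1` gives 6030 nM in this assay.

Compound 3 holds the lowest of the two numbers measured; its nearest neighbour is compound 2, with a 2.5-fold lower number from compound 2 to compound 3 (0.40 log units; beyond the scatter). The remaining value, that of compound 1, is a limit of > 50000 nM in this assay, at which 1 of the 3 values shown sits, and not a number. The steps seen so far all move the hydroxyl on one aryl group: an at least 3.2-fold lower number from compound 1 to compound 2 (0.51 log units; beyond the scatter) and an at least 8.2-fold lower number from compound 1 to compound 3 (0.91 log units; beyond the scatter), both beyond the scatter, and the smaller 2.5-fold lower number from compound 2 to compound 3 (0.40 log units; beyond the scatter).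

Compound 4 `Oc1ccc(-c2cc(-c3ccc(C(F)(F)F)cc3)cc(-c3ccc(O)cc3)n2)cc1` differs from compound 3 by trifluoromethyl in place of fluoro on an aromatic carbon. Going by the values given here, none of the measured steps touches this position; all three concern the hydroxyphenyl ring, so no step bears directly on the fluoro-to-trifluoromethyl change. Among the compounds with values here, with no comparable step in hand, no change beyond the scatter is expected in this assay, in either direction. The expected step of a 1.0-fold lower number from compound 3 to compound 4 (0.00 log units; within the scatter) is therefore taken as within the scatter. Compound 4 is estimated at 6000 nM, with a range from 1500 nM to 25000 nM to reflect the absence of any guiding step.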

Compound 4, half-maximal inhibitory concentration: > 50000 nM
Compound 4: no number, only a limit; the forecaster's own chance of this, stated with the estimate: 12%; at least 8.3-fold (0.92 log units) between middle value and limit.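

Going by these compounds alone, the 4-fluorophenyl group, which no earlier step touched, is not a silent place on the core in this assay: the change to 4-(trifluoromethyl)phenyl gives an at least 8.2-fold higher number from compound 3 to compound 4 (0.91 log units; beyond the scatter). Until now only the placing of the hydroxyl on the hydroxyphenyl ring had moved the read-out, and a second place in the series now moves it too, with the number rising in this case. Compound 4 carries a limit and not a number, so the step gives only a bound and its full size cannot be read: the limit of > 50000 nM in this assay, at which 2 of the 4 values shown sit.

Only fluoro and trifluoromethyl are shown on this ring, so it stays open whether a chloro, a methyl, a methoxy, a nitrile or an amine in the same place would stay near compound 3 at 6030 nM or follow compound 4. It also stays open whether the trifluoromethyl change would act in the same way with the hydroxyl placed as in compound 2, since the compounds shown test it only with the hydroxyl placement of compound 3.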